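A few compounds are considered here, and "the series" means these few. Any claim that something is new, unique, unknown or untested is made for them only; others in the source may bear on it.

Working notes on the series.

Going by the values given here, compound 1 `CCOc1ccc(CCCN2CC=C(CCC(=O)NO)C2=O)cc1` is the lower of the two numbers so far in a functional assay on NUGC-3 cells (Homo sapiens) for inhibition, read by sulforhodamine B assay; a higher number here means a weaker inhibitor of growth, a lower number a stronger inhibitor of growth: compound 1 gives 2200 nM. The other measured member, compound 2 `O=C(CCC1=CCN(CCCCc2ccc(Cl)cc2)C1=O)NO`, gives 3530 nM in this assay; the gap between compound 1 and compound 2 lies within the scatter, so the two values are to be read as indistinguishable and neither compound can be called the stronger on this basis. Among the compounds with values here, no step between a pair of measured compounds differing in one place is available, so nothing about the effect of a single change on the shared core has yet been seen directly.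

Compound 3 `CC(C)c1ccc(CCCN2CC=C(CCC(=O)NO)C2=O)cc1` differs from compound 1 in one place: isopropyl in place of ethoxy on an aromatic carbon. Both the leaving and the entering group are of the same size in heavy atoms; the one hydrogen-bond acceptor of the ethoxy is lost. Within the data shown here, with no measured single-change step to rest on, the expected step in this assay is a 1.1-fold higher number from compound 1 to compound 3 (0.06 log units; within the scatter), that is, none beyond the scatter in either direction. On that basis compound 3 is estimated at 2500 nM in this assay, with a range from 1000 nM to 6300 nM.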

Compound 3, concentration for 50% growth inhibition: 2200 nM
For compound 3 the middle estimate is 1.1-fold (0.06 log units) above the measured one; the measured number falls inside the stated range.
By their numbers in this assay, from the lowest: compounds 1, 3 and 2 (each within the scatter of the next).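

Going by these compounds alone, the first single-change step concerns the aromatic carbon para to a large group: in this assay, isopropyl in place of ethoxy gives no change at the digits printed from compound 1 to compound 3 (within the scatter) and so adds a direct observation to what had been only a comparison of compounds differing in more than one place. For this pair, the loss of the one hydrogen-bond acceptor of the ethoxy, at an equal count of heavy atoms, leaves the growth-inhibition reading within the scatter, so that acceptor is not required to hold the reading of compound 1 in this assay. No separate measurement bears on why the two groups read alike.

Still open, from the compounds shown here alone, is whether an amine or a carboxylic acid on the same aromatic carbon would leave the number as unmoved as isopropyl does, since ethoxy and isopropyl alone say little about groups of another kind or size at this place. Compound 2 differs from compound 1 and from compound 3 in more than one place, so the contribution of a longer chain to the reading in this assay remains unseparated from that of the chlorine on the aromatic ring.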